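The source may hold more compounds than are shown below. What is called first, only, known or untested is meant among the compounds shown, and "the series" means these compounds.

Measured in a functional assay on ACHN cells (Homo sapiens) for inhibition; a higher number here means a weaker inhibitor of growth, a lower number a stronger inhibitor of growth:
compound 1 `C=C1C(=O)O[C@H]2[C@H]1CC/C(COC(=O)N1CCC(F)(F)CC1)=C\CC[C@@]1(C)O[C@@H]21` gives 1790 nM
compound 2 `C=C1C(=O)O[C@H]2[C@H]1CC/C(COC(=O)NCCN1CCCC1)=C\CC[C@@]1(C)O[C@@H]21` gives 3800 nM

Compound 2 at 3800 nM has the higher of the two numbers. Compound 3 `C=C1C(=O)O[C@H]2[C@H]1CC/C(COC(=O)Nc1n[nH]c(SC)n1)=C\CC[C@@]1(C)O[C@@H]21` differs from it as follows: 5-(methylsulfanyl)-1H-1,2,4-triazol-3-yl in place of 2-(pyrrolidin-1-yl)ethyl on an amide-type nitrogen. Within the data shown here, the only measured step that bears on this, a 2.1-fold higher number from compound 1 to compound 2 (0.33 log units; beyond the scatter), is modest and involves a different group, so it suggests a size more than a direction. Among the measured compounds shown here, no measured compound has an aromatic ring here. A similarly modest step toward a lower number is expected in this assay, with the direction uncertain. The expected step is a 1.5-fold lower number from compound 2 to compound 3 (0.18 log units; within the scatter) as estimated here. For compound 3 the estimated value is 2500 nM with a range from 800 nM to 7000 nM.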

Compound 3, concentration for 50% growth inhibition: 1750 nM
Beside the measured number, compound 3's estimate is 1.4-fold (0.15 log units) above it; the measured number falls inside the stated range.
By their numbers in this assay, from the lowest: compounds 3 and 1 (each within the scatter of the next); then compound 2.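

In this assay, the first aromatic ring shown on this amide-type nitrogen, 5-(methylsulfanyl)-1H-1,2,4-triazol-3-yl, replaces 2-(pyrrolidin-1-yl)ethyl with a 2.2-fold lower number from compound 2 to compound 3 (0.34 log units; beyond the scatter), a modest step. Set against the 4,4-difluoropiperidin-1-yl group on the carbonyl carbon, the (5-(methylsulfanyl)-1H-1,2,4-triazol-3-yl)amino group gives a 1.0-fold lower number from compound 1 to compound 3 (0.01 log units; within the scatter), so these two groups cannot be told apart here. Nothing available explains either step. The compounds shown leave open whether the triazole ring or its methylsulfanyl group accounts for the step from the pyrrolidine-bearing chain. As far as these compounds go, how a phenyl group or the unsubstituted triazole would behave on this nitrogen also remains open.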